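A Methoxyphenyl Sulfonamide Expected to Remain Inactive

This account rests on a few compounds, and the source may have more. Where it says the series, first, only, none or still open, it means among the compounds named here.

Compound 1, `CC1CCN(C2CCN(S(=O)(=O)c3ccc(C#N)cc3)CC2)CC1`, gives > 5000 nM in an ADME assay on HCT-116 cells (Homo sapiens) for cytotoxicity, read by CellTiter-Glo, with a stated time of 72 h; a lower number here means a stronger inhibitor, a higher number a weaker inhibitor; this is a limit of the assay.
Compound 2, `CC1CCN(C2CCN(S(=O)(=O)c3ccc(Cl)cc3Cl)CC2)CC1`, gives > 5000 nM in this assay; this too is a limit of the assay.
Compound 3, `CC1CCN(C2CCN(S(=O)(=O)c3cccnc3)CC2)CC1`, gives > 10000 nM in this assay; again a limit of the assay.

Compound 3 therefore stands at the limit of > 10000 nM in this assay, at which 1 of the 3 values shown sits, while the other two measured compounds sit at the limit of > 5000 nM in this assay, at which 2 of the 3 values shown sit. Every value is a limit. Among the measured compounds shown here, none of the measured steps can be read: a step that the two limits leave unreadable from compound 1 to compound 2, a step that the two limits leave unreadable from compound 1 to compound 3 and a step that the two limits leave unreadable from compound 2 to compound 3 are all of unknown size.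

Compound 4, `COc1cccc(S(=O)(=O)N2CCC(N3CCC(C)CC3)CC2)c1`, differs from compound 3 by 3-methoxyphenyl in place of pyridin-3-yl on a sulfonyl sulfur. For the measured compounds named here, the steps that bear on this change, all between aryl groups on the sulfonyl sulfur, are unreadable, so no step beyond the scatter can be foreseen in this assay in either direction. The aryl changes seen so far have not moved any compound off a limit. Compound 4 is therefore expected to remain at or beyond the limits as well, with an estimated value of 20000 nM, ranging from 5000 nM to 80000 nM. The expected step is a step that the limit leaves unreadable from compound 3 to compound 4.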

Compound 4, half-maximal inhibitory concentration: > 5000 nM
Compound 4 was reported as a limit; the forecaster's own chance of this, stated with the estimate: 85%; the middle value does not contradict the limit.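

Compound 4 is reported only as a limit, so none of its steps to compound 1, compound 2 or compound 3 in this assay can be read. The compounds shown leave open where the actual half-maximal inhibitory concentration of each of the four lies, and whether changing the aryl group on the sulfonyl sulfur alters it.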